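The compounds below may be only part of what the source reports. "The series", "measured", "known", "first", "only" and "open" are said of these compounds alone.

Measured so far in an assay for inhibition of Thromboxane-A synthase (Homo sapiens), using microsomes; a lower number here means a stronger inhibitor, a higher number a weaker inhibitor:
- compound 1, `CSc1ccc(OC(C)(C)C2OCC(C/C=C\CCC(=O)O)C(c3cccnc3)O2)c([N+](=O)[O-])c1`, giving 22 nM
- compound 2, `CC(C)(Oc1ccc(F)cc1)C1OCC(C/C=C\CCC(=O)O)C(c2cccnc2)O1`, giving 51 nM

Compound 2 stands at the higher of these two numbers, which means it is the weaker inhibitor of the pair; compound 1 sits below it by a 2.3-fold higher number from compound 1 to compound 2 (0.37 log units; beyond the scatter). That single measured step is the only one available, and it swaps one whole aromatic group for another on an oxygen on a saturated carbon, so it speaks only loosely to the change considered here.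

Compound 3, `Cc1ccc(OC(C)(C)C2OCC(C/C=C\CCC(=O)O)C(c3cccnc3)O2)cc1`, differs from compound 2 by methyl in place of fluoro on an aromatic carbon, para to a large group. Among the measured compounds shown here, the one measured step shows that a different group on this ring moved the number by a modest amount, while the present change is far smaller, touching one atom only. With nothing closer to draw on, the step from compound 2 to compound 3 is expected to be small, around a 1.1-fold lower number from compound 2 to compound 3 (0.05 log units; within the scatter), and could fall in either direction. Compound 3 is therefore estimated at 45 nM, within a range from 18 nM to 110 nM.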

Compound 3, half-maximal inhibitory concentration: 360 nM
Compound 3: middle estimate off by 8.0-fold (0.90 log units), on the low side; measured number above the stated range.
By their numbers in this assay, from the lowest: compound 1; then compound 2; then compound 3.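

In this assay, the exchange of one heavy atom, with methyl in place of fluoro on the aromatic carbon para to a large group, gives a 7.1-fold higher number from compound 2 to compound 3 (0.85 log units; beyond the scatter), which shows that this position does not tolerate every small group equally, even though the two groups count the same in heavy atoms, rings, hydrogen-bond donors and acceptors, and charge. The change also makes compound 3 the weakest inhibitor of the three, with a 16-fold higher number from compound 1 to compound 3 (1.21 log units; beyond the scatter) for the group of seven carbons in place of the larger group of compound 1, so the choice of group on this ring can shift the number widely within an otherwise shared core. No supporting data are available to explain why this small exchange has so large an effect.

From the compounds shown here alone, it remains open where a plain hydrogen, a chloro or a methoxy at this position would fall relative to fluoro and methyl, and so whether fluoro helps, methyl hurts, or both. Going by these compounds, it is also open how much of the standing of compound 1 comes from its nitro group and how much from its methylthio group.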